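The compounds below may be only part of what the source reports. "The series", "measured", "known", "first", "only" and "open" are said of these compounds alone.

In a functional assay on A549 cells (Homo sapiens), read by MTT assay, with a stated time of 72 h (a higher number here means a weaker inhibitor, a lower number a stronger inhibitor), compound 1 `COc1ncnc2c1c(-c1cccs1)cn2[C@@H]1O[C@H](CO)[C@@H](O)[C@H]1O` gives 4850 nM. Compound 2 `COc1nc(N)nc2c1c(-c1cccs1)cn2[C@@H]1O[C@H](CO)[C@@H](O)[C@H]1O` reaches only the limit of this assay, > 20000 nM. The change between them is amino in place of hydrogen on an aromatic carbon, and the step of an at least 4.1-fold higher number from compound 1 to compound 2 (0.61 log units; beyond the scatter) is known only as a lower bound because compound 2 sits at the limit of > 20000 nM in this assay, at which 2 of the 3 values shown sit. Compound 3 `O=c1[nH]cnc2c1c(-c1ccco1)cn2[C@@H]1O[C@H](CO)[C@@H](O)[C@H]1O` likewise sits at the limit of this assay, > 20000 nM. How the cores of compound 1 and compound 3 differ is not broken down here. Compound 4 `Nc1nc2c(c(-c3ccco3)cn2[C@@H]2O[C@H](CO)[C@@H](O)[C@H]2O)c(=O)[nH]1` carries the same kind of change relative to compound 3, (amino in place of hydrogen on an aromatic carbon), though here the amino enters meta to a group of 1 heavy atom rather than meta to a methoxy group. Compound 4 is expected to stay at the limit, with an estimated value of 40000 nM. That expectation means an estimated step that the limit leaves unreadable from compound 3 to compound 4, resting on the weakening seen in an at least 4.1-fold higher number from compound 1 to compound 2 (0.61 log units; beyond the scatter) and on the limit compound 3 already shows.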

Compound 4, half-maximal inhibitory concentration: > 20000 nM
Compound 4: a limit, no number; the forecaster's own chance of this, stated with the estimate: 90%; the middle value lies beyond the limit too.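

Compound 3 and compound 4 both sit at a limit, not a number, so no step can be read between them: the limit of > 20000 nM in this assay, at which 3 of the 4 values shown sit. Going by these compounds, how far amino in place of hydrogen shifts the value on the core of compound 3 stays open.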